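The source may hold more compounds than are shown below. What is called first, only, known or untested is meant among the compounds shown, and "the series" means these compounds.

Compound 1, `Cc1c(O)ccc2cc(-n3cc(-c4ccccc4)nn3)c(=O)oc12`, is the reference point of this account. In a functional assay on MCF7 cells (Homo sapiens) for antiproliferative activity (on this read-out lower numbers stand for stronger inhibition and higher numbers for weaker inhibition), compound 1 gives 25200 nM, the lowest of the two plain numbers seen, with compound 2 nearest to it. Compound 2, `CC(=O)Oc1ccc2cc(-n3cc(-c4ccccc4)nn3)c(=O)oc2c1C`, gives 40800 nM in this assay, and the step of a 1.6-fold higher number from compound 1 to compound 2 (0.21 log units; within the scatter) stays within the scatter. Compound 3, `CC(=O)Oc1ccc2cc(-n3cc(-c4ccc(N(C)C)cc4)nn3)c(=O)oc2c1C`, carries a dimethylamino group on the phenyl ring. In this assay compound 3 reaches only a limit, > 100000 nM. The step of an at least 2.4-fold higher number from compound 2 to compound 3 (0.38 log units; beyond the scatter) is therefore read against (the limit of > 100000 nM in this assay, at which 1 of the 3 values shown sits), and counts as at least a modest weakening.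

The unmeasured compound 4, `Cc1c(O)ccc2cc(-n3cc(-c4cc5ccccc5[nH]4)nn3)c(=O)oc12`, differs from compound 1 by 1H-indol-2-yl in place of phenyl on an aromatic carbon. For the measured compounds named here, no measured step exchanges the whole phenyl ring; the only step that touches that ring is the one from compound 2 to compound 3, which weakened activity at least modestly. A larger bicyclic group in place of phenyl is a change of a different kind, so that step offers only loose guidance. The expectation is a step of roughly a 1.1-fold lower number from compound 1 to compound 4 (0.06 log units; within the scatter), with wide uncertainty in either direction. Compound 4 is estimated at 22000 nM in this assay, within a range from 6000 nM to 80000 nM.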

Compound 4, half-maximal inhibitory concentration: 38300 nM
For compound 4 the middle estimate is 1.7-fold (0.24 log units) below the measured one, within the range that was stated.
By their numbers in this assay, from the lowest: compounds 1, 4 and 2 (each within the scatter of the next). At a limit, above all of these: compound 3.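

In this assay, the step of a 1.5-fold higher number from compound 1 to compound 4 (0.18 log units; within the scatter) shows that this place on the five-membered aromatic ring with 3 nitrogen can take a complete exchange of phenyl for 1H-indol-2-yl without a shift beyond the scatter. The earlier compounds shown here all kept phenyl here, with dimethylamino on it in compound 3, so only compound 4 shows that a larger group with a second ring and a hydrogen-bond donor can stand at this place and leave the number within the scatter of that of compound 1. For the compounds shown here, nothing given here accounts for this small step, and the one limit among the values concerns a different change.

Open, as far as these compounds go, is whether the indole ring hydrogen on nitrogen plays any part, which a 1-methylindol-2-yl group at the same place would address, and how a pyridyl ring or a phenyl ring bearing a carboxylic acid or a methoxy group would read there. Also open, from the compounds shown here alone, is whether 1H-indol-2-yl would read the same way on the core of compound 2, with its acetyl on the oxygen.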